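A Sulfonyl Swap on a Spirocyclic Amide Scaffold

The compounds below may be only part of what the source reports. "The series", "measured", "known", "first", "only" and "open" are said of these compounds alone.

Measured so far:
compound 1 `O=C(Nc1cccc(S(=O)(=O)C2CCCC2)n1)c1ccc(NCCO)cc1N1CCC2(CC1)CC2`: > 399 mL.min-1.g-1
compound 2 `O=C(Nc1cccc(S(=O)(=O)N2CCCC2)c1)c1cccnc1N1CCC2(CC1)CC2`: > 399 mL.min-1.g-1
compound 3 `CC(C)(C)NS(=O)(=O)c1cccc(NC(=O)c2ncc(NS(C)(=O)=O)nc2N2CCC3(CC2)CC3)n1`: 127 mL.min-1.g-1

In an ADME assay on microsomes from liver (Homo sapiens) for metabolic stability, read by LC-MS, with a stated time of 40 min, tested at 0.5 uM (on this read-out higher numbers stand for fast clearance and lower numbers for slow clearance), compound 1 gives > 399 mL.min-1.g-1, which is a limit of the assay rather than a number. Compound 2 likewise gives > 399 mL.min-1.g-1, again only a limit. Compound 3 gives a measured number, 127 mL.min-1.g-1. Compound 2 therefore stands at the limit of > 399 mL.min-1.g-1 in this assay, at which 2 of the 3 values shown sit, so its distance from the other two cannot be stated. Compound 4 `CC(C)(CO)S(=O)(=O)c1cccc(NC(=O)c2cccnc2N2CCC3(CC2)CC3)c1` differs from compound 2 in one place: 1-(hydroxymethyl)-1-methylethyl in place of pyrrolidin-1-yl on a sulfonyl sulfur. For the measured compounds named here, no measured step of this kind is available for comparison. Compound 4 is expected to show slower clearance than the limit of compound 2, an estimated step of an at least 1.5-fold lower number from compound 2 to compound 4 (0.20 log units; that floor lies within the scatter), although a value again at the limit is quite possible. The estimate for compound 4 is 250 mL.min-1.g-1, within a range from 100 mL.min-1.g-1 to 399 mL.min-1.g-1.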

Compound 4, intrinsic clearance in microsomes: 154 mL.min-1.g-1
For compound 4 the middle estimate is 1.6-fold (0.21 log units) above the measured one; measured number inside the range.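

For the compounds shown here, on the sulfonyl sulfur, replacing pyrrolidin-1-yl with 1-(hydroxymethyl)-1-methylethyl gives the first step that can be read at this position in this assay: an at least 2.5-fold lower number from compound 2 to compound 4 (0.41 log units; beyond the scatter). A change in this one group is therefore enough to bring clearance down from the limit on the shared core. The value of compound 2 is a limit and not a number, so the full size of the step stays unknown: the limit of > 399 mL.min-1.g-1 in this assay, at which 2 of the 4 values shown sit.

The compounds shown do not separate the roles of the hydroxyl, the lost ring and the change from nitrogen to carbon on the sulfur. Morpholin-4-yl or an open-chain diethylamino group on the same sulfur would help to tell these apart.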